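The compounds below may be only part of what the source reports. "The series", "measured", "known", "first", "only" and "open" are said of these compounds alone.

Measured compounds:
- compound 1, `CCNc1nc(NCc2ccc(C(=O)Nc3ccc(F)cc3)cc2)c2ccccc2n1`: in a functional assay on SW480 cells (Homo sapiens) for inhibition, read by luminescence and resazurin assay, with a stated time of 3 days (on this read-out higher numbers stand for weaker inhibition and lower numbers for stronger inhibition), compound 1 gives 2500 nM
- compound 2, `CCCNc1nc(NCc2ccc(C(=O)Nc3ccc(F)cc3)cc2)c2ccccc2n1`: in this assay compound 2 gives 1600 nM

Among the compounds with values here, compound 2 stands at the lower of the two numbers measured so far, but its nearest neighbour is compound 1, and the step of a 1.6-fold lower number from compound 1 to compound 2 (0.19 log units; within the scatter) is within the scatter, so the two compounds cannot be told apart on this read-out.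

Compound 3, `CN(C)c1nc(NCc2ccc(C(=O)Nc3ccc(F)cc3)cc2)c2ccccc2n1`, has not been measured. It differs from compound 2 in one place: dimethylamino in place of propylamino on an aromatic carbon. The change sits on an aromatic carbon of the shared core, between two ring nitrogen atoms, meta to a fused ring and para to a fused ring.

Within the data shown here, only one measured step bears on this position, a 1.6-fold lower number from compound 1 to compound 2 (0.19 log units; within the scatter), and it concerns a change of chain length while the hydrogen-bond donor is kept. Among the measured compounds shown here, the change to compound 3 removes that donor, which no measured pair tests. For the measured compounds named here, the one step known at this place is small, so the expected step of a 1.6-fold higher number from compound 2 to compound 3 (0.19 log units; within the scatter) for compound 3 is likewise small, with the direction uncertain. Compound 3 is therefore estimated at 2500 nM, within a range from 900 nM to 8000 nM.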

Compound 3, half-maximal inhibitory concentration: 2600 nM
Compound 3: middle estimate off by 1.0-fold (0.02 log units), on the low side, and the stated range covers the measured number.
By their numbers in this assay, from the lowest: compounds 2, 1 and 3 (each within the scatter of the next).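

At this position, on an aromatic carbon between two ring nitrogen atoms, dimethylamino in place of propylamino gives a 1.6-fold higher number from compound 2 to compound 3 (0.21 log units; within the scatter) in this assay, and dimethylamino in place of ethylamino gives a 1.0-fold higher number from compound 1 to compound 3 (0.02 log units; within the scatter). The earlier pair varied only the chain length and kept the hydrogen-bond donor on the nitrogen, whereas these steps go from a group with 1 hydrogen-bond donor to one with 0, and neither can be told apart from the scatter on this read-out. The amine hydrogen at this place is therefore not shown to matter in this assay, and ethylamino, propylamino and dimethylamino cannot be separated here, although no evidence is available to account for this result.

The compounds shown leave open whether this tolerance holds for groups further from these three, such as a longer chain like butylamino, an unsubstituted amino group, a morpholine ring or a group carrying a carboxylic acid. They also leave open whether any group at this position can move the number beyond the scatter, since all three compounds lie within it of one another.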